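The source may report more compounds than this note shows. Statements on the series, on what has been measured and on what is new or still open speak of the compounds shown alone.

Measured in a functional assay on HCT-116 cells (Homo sapiens), read by MTT assay, with a stated time of 72 h (a higher number here means a weaker inhibitor, a lower number a stronger inhibitor), all three as limits:
- compound 1 `CSc1ncnc2c1c(-c1cccs1)cn2[C@@H]1O[C@H](CO)[C@@H](O)[C@H]1O`: > 20000 nM
- compound 2 `CNc1ncnc2c1c(-c1cccs1)cn2[C@@H]1O[C@H](CO)[C@@H](O)[C@H]1O`: > 20000 nM
- compound 3 `Cc1ncnc2c1c(-c1ccoc1)cn2[C@@H]1O[C@H](CO)[C@@H](O)[C@H]1O`: > 20000 nM

Compound 3 gives no number, only a limit. Going by the values given here, it stands with the other two compounds, so the series so far shows (the limit of > 20000 nM in this assay, at which 3 of the 3 values shown sit).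

Compound 4 `Cc1ncnc2c1c(-c1cccs1)cn2[C@@H]1O[C@H](CO)[C@@H](O)[C@H]1O` differs from compound 3 by thiophen-2-yl in place of furan-3-yl on an aromatic carbon; in words, thiophen-2-yl in place of furan-3-yl on an aromatic carbon.

Among the compounds with values here, no measured step covers this exchange. Within the data shown here, the only step available is a step that the two limits leave unreadable from compound 1 to compound 2, which concerns methylamino in place of methylsulfanyl and gives no size to carry over. Compound 1 and compound 2 already carry thiophen-2-yl, and both give only limits.

The expectation therefore rests on these limits, and no change beyond the scatter is expected in this assay, though a measurable number cannot be ruled out. The estimated move is a number no higher from compound 3 to compound 4 (the limit leaves the size open).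

Compound 4 is expected at 20000 nM, with an estimated range of 5000 nM to 40000 nM.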

Compound 4, half-maximal inhibitory concentration: > 20000 nM
Compound 4 gave a limit, no number; the forecaster's own chance of this, stated with the estimate: 70%; the middle value sits exactly at the limit.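

In this assay compound 4 gives > 20000 nM, a limit and not a number. No step between compound 4 and compound 1, compound 2 or compound 3 can be read: the limit of > 20000 nM in this assay, at which 4 of the 4 values shown sit.

Going by these compounds, whether any group exchanged on the shared core gives a measurable number in this assay stays open.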